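Swapping thiophen-3-yl for 2-chlorophenyl on the aminothiophene core

The source may report more compounds than this note shows. Statements on the series, on what has been measured and on what is new or still open speak of the compounds shown alone.

Of the compounds shown here, three sharing one core have been tested in a functional assay on FM3A cells (Mus musculus) for antiproliferative activity; on this read-out lower numbers stand for stronger inhibition and higher numbers for weaker inhibition. Compound 1 `COc1cc(C(=O)c2sc(-c3ccc(Cl)cc3)cc2N)cc(OC)c1OC` carries a 4-chlorophenyl group and in this assay gives 90 nM. Compound 2 `CCOc1ccc(-c2cc(N)c(C(=O)c3cc(OC)c(OC)c(OC)c3)s2)cc1` gives 510 nM. Compound 3 `COc1cc(C(=O)c2sc(-c3ccsc3)cc2N)cc(OC)c1OC`, which carries thiophen-3-yl, gives 3.7 nM and stands lowest of the three: the step of a 24-fold lower number from compound 1 to compound 3 (1.39 log units; beyond the scatter) and the step of a 140-fold lower number from compound 2 to compound 3 (2.14 log units; beyond the scatter) both lie well beyond the scatter, so compound 3 is clearly the strongest inhibitor of the set.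

Compound 4 `COc1cc(C(=O)c2sc(-c3ccccc3Cl)cc2N)cc(OC)c1OC` is not yet measured. It differs from compound 3 by 2-chlorophenyl in place of thiophen-3-yl on an aromatic carbon. The step that bears most directly on this change is a 24-fold lower number from compound 1 to compound 3 (1.39 log units; beyond the scatter), where a chlorophenyl group gave way to thiophen-3-yl and the number dropped sharply; the step of a 140-fold lower number from compound 2 to compound 3 (2.14 log units; beyond the scatter) points the same way. Compound 4 reverses the direction of that exchange, returning a chlorophenyl group, now 2-chlorophenyl, in place of thiophen-3-yl. A large rise in the number is therefore expected for compound 4, roughly a 27-fold higher number from compound 3 to compound 4 (1.43 log units; beyond the scatter), because compound 1 with 4-chlorophenyl sits at 90 nM. The value of compound 4 in this assay is estimated at 100 nM, within a range of 25 nM to 400 nM.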

Compound 4, half-maximal inhibitory concentration: 34 nM
Estimate against measurement, compound 4: 2.9-fold (0.47 log units) above; the measured number falls inside the stated range.
By their numbers in this assay, from the lowest: compound 3; then compound 4; then compound 1; then compound 2.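

In this assay, among these compounds, the result shows that this position responds not only to the kind of ring it carries but also to where the chlorine sits on a phenyl ring: a 2.6-fold lower number from compound 1 to compound 4 (0.42 log units; beyond the scatter), a modest step beyond the scatter that the earlier compounds could not reveal. Thiophen-3-yl remains the best group seen here, yet the cost of leaving it depends on the chlorophenyl group that enters, since a 9.2-fold higher number from compound 3 to compound 4 (0.96 log units; beyond the scatter), whereas the reverse of a 24-fold lower number from compound 1 to compound 3 (1.39 log units; beyond the scatter) is a larger change. Compound 4 also improves clearly on the ethoxy-bearing analogue, as a 15-fold lower number from compound 2 to compound 4 (1.18 log units; beyond the scatter), although that step changes both the substituent and its place on the phenyl ring, so it cannot assign the gain to either one.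

Nothing shown here accounts for these differences. The compounds also leave open how thiophen-2-yl, 3-chlorophenyl or 2-ethoxyphenyl would read at this position, and the last of these would separate the effect of the ethoxy group from that of its place on the ring.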